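Varying the aryl amide on a shared core

This account rests on a few compounds, and the source may have more. Where it says the series, first, only, none or still open, it means among the compounds named here.

Of the compounds shown here, two of a shared core have been measured in a functional assay on HL-60 cells (Homo sapiens) for antiproliferative activity, with a stated time of 24 h; on this read-out lower numbers stand for stronger inhibition and higher numbers for weaker inhibition. Compound 1 `NC(=O)c1c(NC(=O)c2ccccc2Cl)sc2c1CCN(C(=S)Nc1cc(C(F)(F)F)cc(C(F)(F)F)c1)C2` gives 6500 nM. Compound 2 `Cc1ccc(C(=O)Nc2sc3c(c2C(N)=O)CCN(C(=S)Nc2cc(C(F)(F)F)cc(C(F)(F)F)c2)C3)cc1` gives 11800 nM. Among the two numbers compound 2 holds the higher one, yet the step of a 1.8-fold higher number from compound 1 to compound 2 (0.26 log units; within the scatter), so the two compounds cannot be told apart on this read-out. Compound 3 `NC(=O)c1c(NC(=O)c2cccc([N+](=O)[O-])c2)sc2c1CCN(C(=S)Nc1cc(C(F)(F)F)cc(C(F)(F)F)c1)C2` has not yet been measured. It differs from compound 2 in one place: 3-nitrophenyl in place of 4-methylphenyl on a carbonyl carbon. For the measured compounds named here, only one measured step bears on this position, namely a 1.8-fold higher number from compound 1 to compound 2 (0.26 log units; within the scatter), and no measured compound carries a 3-nitrophenyl on the carbonyl carbon, so the new group has no direct precedent here. Going by the values given here, since the one known exchange at this position did not move the number beyond the scatter, a step of size a 1.3-fold lower number from compound 2 to compound 3 (0.12 log units; within the scatter) is expected in this assay, meaning no change beyond the scatter in either direction, with a somewhat wide range to allow for the untested group. Compound 3 is therefore estimated at 9000 nM, within a range from 3000 nM to 30000 nM.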

Compound 3, half-maximal inhibitory concentration: 16400 nM
Beside the measured number, compound 3's estimate is 1.8-fold (0.26 log units) below it; the measured number falls inside the stated range.
By their numbers in this assay, from the lowest: compounds 1, 2 and 3 (each within the scatter of the next, the first and the last beyond it).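

In this assay, the second exchange at this position gives a 1.4-fold higher number from compound 2 to compound 3 (0.14 log units; within the scatter) and so also stays inside the scatter, even though the 3-nitrophenyl brings in two hydrogen-bond acceptors where the 4-methylphenyl has none. For the compounds shown here, what the earlier compounds could not show is that the choice of aryl group on this carbonyl carbon can matter at all: 3-nitrophenyl in place of 2-chlorophenyl gives a 2.5-fold higher number from compound 1 to compound 3 (0.40 log units; beyond the scatter) and is a modest step beyond the scatter, while compound 2 lies within the scatter of both other compounds and so cannot be ranked against either. No evidence at hand explains this small spread.

As far as these compounds go, all three groups at this position are substituted phenyl rings, so it stays open whether a phenyl ring carrying an amine or a carboxylic acid, or a plain alkyl chain in place of the ring, would move the number further than these steps do. The compounds shown also share the rest of the core unchanged, which leaves open whether the small spread seen here would hold with another group in place of the bis(trifluoromethyl)phenyl part.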